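The source may hold more compounds than are shown below. What is called first, only, known or untested is meant among the compounds shown, and "the series" means these compounds.

Measured so far in a functional assay on the whole organism (blood) with Rattus norvegicus as the target, with stated times of 24 h and 1 h, at a dose of 5 mg/kg by the intraperitoneal route; a lower number here means a weaker effect, a higher number a stronger effect of the compound at the dose given:
compound 1, `CCCNC(=O)NS(=O)(=O)N1CCC(CCNC(=O)c2cc(Cl)ccc2OC)CC1`, gives 11%
compound 2, `CCCNC(=O)NS(=O)(=O)N1CCC(CCNC(=O)c2cc(C(F)(F)F)nn2C)CC1`, gives 11%
compound 3, `O=C(NC1CCCCC1)NS(=O)(=O)N1CCC(CCNC(=O)c2cscn2)CC1`, gives 23%

Compound 3 stands highest of the three numbers, beyond the scatter above both compound 1 and compound 2. Compound 4, `CCCNC(=O)NS(=O)(=O)N1CCC(CCNC(=O)c2cscn2)CC1`, differs from compound 3 in one place: propyl in place of cyclohexyl on an amide-type nitrogen. Among the compounds with values here, no measured step varies this substituent; the only measured step, no change at the digits printed from compound 1 to compound 2 (within the scatter), changes the acyl group while propyl is held, and shows no change within the scatter. Compound 1 and compound 2 carry propyl and give the low numbers; compound 3 carries cyclohexyl together with its own acyl group and gives the high one. Which of these two differences carries the gap cannot be separated on these data. For compound 4 a downward step of a number 8 percentage points lower from compound 3 to compound 4 (within the scatter) is expected, toward the propyl compounds. Compound 4 is estimated at 15%, range 4% to 27%.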

Compound 4, a percentage reported as activity, at one dose (the size of the read-out at that dose, not a potency): 10%
For compound 4 the middle estimate is 5 percentage points above the measured one; low and high end bracket the measured number.
By their numbers in this assay, from the lowest: compounds 4, 1 and 2 (each within the scatter of the next); then compound 3.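

In this assay, within the data shown here, propyl in place of cyclohexyl on the amide-type nitrogen gives a number 13 percentage points lower from compound 3 to compound 4 (beyond the scatter) with the 1,3-thiazol-4-yl acyl group held, the first measured step at this position. With propyl held, a number 1 percentage points lower from compound 2 to compound 4 (within the scatter) and a number 1 percentage points lower from compound 1 to compound 4 (within the scatter) add to the earlier acyl change, and no acyl change among these propyl compounds lies beyond the scatter. No available evidence explains the cyclohexyl to propyl step.

As far as these compounds go, whether that step recurs with the 5-chloro-2-methoxyphenyl or pyrazolyl acyl groups remains open. Also open, from the compounds shown here alone, is where a phenyl or hexyl group on the same nitrogen would fall.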